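This account rests on a few compounds, and the source may have more. Where it says the series, first, only, none or still open, it means among the compounds named here.

Compound 1: `COc1cccc(-n2cc(COc3c(/C=C\C(=O)O)ccc(OC)c3CC=C(C)C)nn2)c1` — in a functional assay on COLO 205 cells (Homo sapiens) for cytotoxicity, read by MTT assay, with a stated time of 24 h (on this read-out higher numbers stand for weaker inhibition and lower numbers for stronger inhibition), compound 1 gives "not determined" (no result reported).
Compound 2: `COc1ccc(/C=C\C(=O)O)c(OCc2cn(-c3ccc(CO)cc3)nn2)c1CC=C(C)C` — in this assay compound 2 gives 19300 nM.

Compound 2 therefore stands alone: it carries the only number shown in this assay, since compound 1 came back without a result. Within the data shown here, nothing in this set shows how a change at the aromatic nitrogen shifts the read-out, so there is no measured step to lean on.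

Compound 3 is `COc1ccc(/C=C\C(=O)O)c(OCc2cn(-c3nc4ccccc4s3)nn2)c1CC=C(C)C`. It keeps the shared core of compound 2 and differs in one place: 1,3-benzothiazol-2-yl in place of 4-(hydroxymethyl)phenyl on an aromatic nitrogen. Among the measured compounds shown here, with no measured pair to compare against, a change of this kind could move the result either way, and the most defensible expectation is a step that stays inside the usual scatter or only slightly beyond it.

On that basis compound 3 is estimated at 15000 nM in this assay, with a range from 4000 nM to 55000 nM. The step from compound 2 that this estimate means is expected to be a 1.3-fold lower number from compound 2 to compound 3 (0.11 log units; within the scatter), no more than the scatter of repeated measurements would allow.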

Compound 3, half-maximal inhibitory concentration: 20200 nM
Compound 3: the middle estimate sits 1.3-fold (0.13 log units) below what was measured; measured number inside the range.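

Among these compounds, this is the first measured step at this position: in this assay, putting 1,3-benzothiazol-2-yl in place of 4-(hydroxymethyl)phenyl on the aromatic nitrogen gives a 1.0-fold higher number from compound 2 to compound 3 (0.02 log units; within the scatter). The exchange is a real one in structure, since a single six-membered aromatic ring of carbon carrying a hydrogen-bond donor gives way to a fused pair of aromatic rings that holds nitrogen and sulfur and has no such donor, yet this read-out cannot tell the two compounds apart. For this one pair, then, the position accepts that change without a measurable shift, and no measurement shown here explains why the two compounds read alike.

Going by these compounds, both groups compared here carry aromatic rings, so it remains open whether an amine, a short chain such as ethyl or a longer alkyl chain on this nitrogen would read the same in this assay. Compound 1 gives "not determined" (no result reported), so it adds no second comparison at this position, and a single step cannot show whether any group placed here would shift the number beyond the scatter.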